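The source may hold more compounds than are shown below. What is called first, only, known or untested is meant among the compounds shown, and "the series" means these compounds.

Working notes on the series. In a physicochemical assay for solubility, in phosphate buffer, with a stated time of 18 h (a lower number here means a less soluble compound, a higher number a more soluble compound), compound 1 (`CC(C)(C)c1nc(CCCCCC#N)c2c(N)c(C#N)c(N)nc2n1`) gives 6000 nM as a measured number. Compound 2 (`CC(C)(C)c1nc(-c2nccs2)c2c(N)c(C#N)c(N)nc2n1`) stands at < 1500 nM in this assay, and this is a limit of the assay, not a number. Compound 3 (`CC(C)(C)c1nc(-c2ccccn2)c2c(N)c(C#N)c(N)nc2n1`) has pyridin-2-yl in place of 1,3-thiazol-2-yl on an aromatic carbon, next to the ring nitrogen, and the counted difference is pyridin-2-yl in place of 1,3-thiazol-2-yl on an aromatic carbon in full. Among the measured compounds shown here, one measured step bears on this position: an at least 4.0-fold lower number from compound 1 to compound 2 (0.60 log units; beyond the scatter) with 1,3-thiazol-2-yl replacing 5-cyanopentyl. That step took out a chain, whereas this one exchanges one aromatic ring for another, so no step beyond the scatter is expected in this assay, and the expected step is a step that the limit leaves unreadable from compound 2 to compound 3 on that basis. Compound 3 is estimated at 1200 nM within an expected range of 400 nM to 3000 nM in this read-out.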

Compound 3, solubility: 87000 nM
Compound 3: middle estimate off by 73-fold (1.86 log units), on the low side; the whole stated range lies below it.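

In this assay, exchanging 1,3-thiazol-2-yl for pyridin-2-yl on the aromatic carbon next to the ring nitrogen gives an at least 58-fold higher number from compound 2 to compound 3 (1.76 log units; beyond the scatter), so at this position the read-out differs widely between two aromatic rings, not only between a chain and a ring. Replacing the 5-cyanopentyl chain with an aromatic ring therefore has no single direction here: compound 2 lies lower than compound 1, whereas compound 3 goes against that with a 15-fold higher number from compound 1 to compound 3 (1.16 log units; beyond the scatter). Compound 2 is known only as a limit of the assay, so the first of these steps has no upper bound: the limit of < 1500 nM in this assay, at which 1 of the 3 values shown sits.

The two rings differ in ring size, in hetero atom count and in sulfur, and the compounds shown do not separate these differences. Phenyl, pyridin-3-yl or 1,3-oxazol-2-yl at this carbon would bear directly on that question.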